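This account rests on a few compounds, and the source may have more. Where it says the series, first, only, none or still open, it means among the compounds named here.

Measured compounds in an assay on isolated protein for inhibition of Calpain-1 catalytic subunit (Sus scrofa), read by FRET; a higher number here means a weaker inhibitor, a lower number a stronger inhibitor:
compound 1 `O=C(O)/C(S)=C/c1ccc(Cl)cc1` gives 2600 nM
compound 2 `O=C(O)/C(S)=C/c1c[nH]c2ccc(I)cc12` gives 100 nM
compound 3 `O=C(O)/C(S)=C/c1cccc(Br)c1` gives 4000 nM

Compound 1 stands second highest of the three numbers in this assay. Its nearest neighbour is compound 3, whose value lies within the scatter of that of compound 1, so no order can be read between the two. Compound 2, on a different core, sits well beyond the scatter on the lower side.

The next compound in the series is compound 4 `O=C(O)/C(S)=C/c1ccc(I)cc1`. It differs from compound 1 in a single place: iodo in place of chloro on an aromatic carbon. Within the data shown here, the measured set holds no single-change pair that isolates a halogen swap on this core, so no step of this kind is known here. Compound 2 carries an iodo group, yet on another core, and its value cannot be transferred.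

Compound 4 is expected to give 1800 nM in this assay, within 700 nM to 4500 nM. For compound 4 the expected step is a 1.4-fold lower number from compound 1 to compound 4 (0.16 log units; within the scatter), a small move downward that is estimated not to exceed the scatter.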

Compound 4, half-maximal inhibitory concentration: 2200 nM
For compound 4 the middle estimate is 1.2-fold (0.09 log units) below the measured one, within the range that was stated.
By their numbers in this assay, from the lowest: compound 2; then compounds 4, 1 and 3 (each within the scatter of the next).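

Among these compounds, this is the first single-change pair on the shared core in this assay: iodo in place of chloro on an aromatic carbon gives a 1.2-fold lower number from compound 1 to compound 4 (0.07 log units; within the scatter). At this place, para to a group of 6 heavy atoms, the two halogens therefore cannot be told apart in this read-out, and the position accepts iodo as well as chloro with no readable shift. No supporting data bear on why the pair reads the same.

On these data alone, whether the same flat reading holds for a group other than a halogen at this place, such as a methoxy group or an amine, stays open. Among the compounds shown here, no single-change pair connects compound 2, at 100 nM, to this core, so what its different core contributes also remains unresolved.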